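The source may report more compounds than this note shows. Statements on the series, on what has been measured and on what is new or still open speak of the compounds shown alone.

Compound 2, `CCN(CC)CCCOc1c(OCc2ccccc2)cc(O)c2c(=O)cc(-c3ccccc3)oc12`, was tested in a functional assay on MCF7 cells (Homo sapiens) for cytotoxicity, read by MTT assay, with a stated time of 72 h (on this read-out higher numbers stand for weaker inhibition and lower numbers for stronger inhibition), where compound 2 gives 3210 nM. Compound 1, `COc1c(OCCCCN2CCN(C)CC2)cc(O)c2c(=O)cc(-c3ccc(C(F)(F)F)cc3)oc12`, gives 2980 nM in this assay; the two numbers lie within the scatter of each other, so neither compound can be set apart from the other on this read-out. Compound 3, `O=c1cc(-c2ccccc2)oc2c(OCCCCN3CCCC3)c(OCc3ccccc3)cc(O)c12`, differs from compound 2 by (pyrrolidin-1-yl)methyl in place of diethylamino on a saturated chain carbon, three bonds along the chain from an oxygen on an aromatic ring. For the measured compounds named here, no measured pair shows what this change does, and as it touches only the amine at the end of the chain, the expected step of a 1.1-fold lower number from compound 2 to compound 3 (0.03 log units; within the scatter) is none beyond the scatter. Compound 3 is accordingly estimated at 3000 nM, with a range from 1400 nM to 6500 nM.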

Compound 3, half-maximal inhibitory concentration: 1890 nM
The estimate for compound 3 lay 1.6-fold (0.20 log units) above the measured number; measured number inside the range.
By their numbers in this assay, from the lowest: compounds 3, 1 and 2 (each within the scatter of the next).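

In this assay, for the compounds shown here, the one pair that differs in a single place gives a 1.7-fold lower number from compound 2 to compound 3 (0.23 log units; within the scatter), so at this position, three bonds along the chain from an oxygen on an aromatic ring, (pyrrolidin-1-yl)methyl cannot be told apart from diethylamino. Going by these compounds alone, this is the first direct reading of an exchange at the chain end, and it shows no effect beyond the scatter. No evidence on hand explains this result. From the compounds shown here alone, it remains open whether a morpholine or a piperidine at the chain end, or a shorter chain carrying the pyrrolidine, would give a step beyond the scatter.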